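Aryl to Benzyl Swap on a Shared Core, Ehrlich Cells

The source may report more compounds than this note shows. Statements on the series, on what has been measured and on what is new or still open speak of the compounds shown alone.

Measured compounds:
Compound 1 `Cc1ccc(C2C(C#N)=C(N)N(c3ccc(S(N)(=O)=O)cc3)C3=C2C(=O)CCC3)cc1` gives 30%.
Compound 2 `COc1ccc(C2C(C#N)=C(N)N(c3ccc(S(N)(=O)=O)cc3)C3=C2C(=O)CCC3)cc1` gives 30%.

Both were tested in a functional assay on Ehrlich cells (Mus musculus) for antiproliferative activity, read by trypan blue exclusion, with a stated time of 2 h, tested at 10 ug/mL; on this read-out higher numbers stand for a stronger effect at the one concentration tested and lower numbers for a weaker effect. In this assay compound 1 gives 30% and compound 2 gives 30%. Among the measured compounds shown here, the single change between them, methoxy in place of methyl on an aromatic carbon, produced no change at the digits printed from compound 1 to compound 2 (within the scatter). Compound 2 thus stands level with compound 1 at the digits shown.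

Compound 3 `COc1cc(CC2C(C#N)=C(N)N(c3ccc(S(N)(=O)=O)cc3)C3=C2C(=O)CCC3)ccc1O` has not yet been measured. Against compound 2 the difference is 4-hydroxy-3-methoxybenzyl in place of 4-methoxyphenyl on a saturated ring carbon. For the measured compounds named here, this is a larger structural change than the one between compound 1 and compound 2, since a 4-methoxyphenyl leaves and a 4-hydroxy-3-methoxybenzyl enters on the saturated ring carbon. Going by the values given here, the only measured step available concerns a small change on the aromatic ring and stayed within the scatter, so there is no ground for expecting movement, but that step does not cover a change of this size. Compound 3 is therefore estimated at 30%, within a range from 12% to 48%. The step of no change at the digits printed from compound 2 to compound 3 (within the scatter) that this estimate implies is expected to stay within the scatter, with a wide range reflecting the untested size of the change.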

Compound 3, a percentage reported as activity, at one concentration (the size of the read-out at that concentration, not a potency): 0%
For compound 3 the middle estimate is 30 percentage points above the measured one; measured number below the stated range.
By their numbers in this assay, from the lowest: compound 3; then compounds 1 and 2 (each within the scatter of the next).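

In this assay, moving to the 4-hydroxy-3-methoxybenzyl group on the saturated ring carbon gives a number 30 percentage points lower from compound 2 to compound 3 (beyond the scatter), and the same group gives a number 30 percentage points lower from compound 1 to compound 3 (beyond the scatter) when it stands in place of 4-methylphenyl. Among the compounds shown here, the earlier pair showed only that a small change on the aromatic ring left the read-out level, whereas these steps show that the read-out at this single concentration does respond to what sits on this saturated ring carbon, and that the 4-hydroxy-3-methoxybenzyl group is the poorer of the groups seen there. No measurement available here gives a reason for the loss.

This swap changes several things at once, adding a linking carbon between the ring and the aromatic group as well as a hydroxy group and a second oxygen substituent, so the compounds shown cannot say which of these matters. A plain benzyl, a 4-methoxybenzyl or a 4-hydroxyphenyl group on the same carbon would begin to separate these parts, and nothing shown tells whether any group here can rise clearly above the level of compound 1 and compound 2.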